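The source may hold more compounds than are shown below. What is called first, only, known or untested is meant among the compounds shown, and "the series" means these compounds.

Working notes on the series. Compound 1 `COC(=O)CC/C(C)=C/Cc1c(OC)c(C)c2c(c1OCC#CCN1CCN(c3ccc(C)cc3)CC1)C(=O)OC2` carries a 4-methylphenyl group at the end of its side chain. In a functional assay on A549 cells (Homo sapiens) for inhibition, read by sulforhodamine B assay (a higher number here means a weaker inhibitor, a lower number a stronger inhibitor), compound 1 gives only a limit, > 50000 nM, and no number. Compound 2 `COC(=O)CC/C(C)=C/Cc1c(OC)c(C)c2c(c1OCC#CCN1CCN(C(c3ccccc3)c3ccccc3)CC1)C(=O)OC2` gives 32700 nM in this assay, and compound 3 `COC(=O)CC/C(C)=C/Cc1c(OC)c(C)c2c(c1OCC#CCN1CCC(C(=O)OC)CC1)C(=O)OC2` gives 40500 nM. Compound 1 thus stands at the limit of this assay, which is where the limit of > 50000 nM in this assay, at which 1 of the 3 values shown sits, places it, and the numbers for compound 2 and compound 3 sit close to that limit, so no order among the three can be read from them.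

Compound 4 `COC(=O)CC/C(C)=C/Cc1c(OC)c(C)c2c(c1OCC#CCN1CCN(c3ccc(O)cc3)CC1)C(=O)OC2` differs from compound 1 by hydroxy in place of methyl on an aromatic carbon. No step between measured compounds covers this change, and the shown values offer no direction for it. The expected step from compound 1 to compound 4 is an at least 1.2-fold lower number from compound 1 to compound 4 (0.09 log units; that floor lies within the scatter), which is taken to lie within the scatter rather than beyond it. Compound 4 is expected to give about 40000 nM in this assay, with a range from 15000 nM to 100000 nM, and a fair chance that only a limit is reported again.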

Compound 4, half-maximal inhibitory concentration: > 50000 nM
Compound 4 was reported as a limit; the forecaster's own chance of this, stated with the estimate: 50%; middle value at least 1.2-fold (0.09 log units) away from the limit.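

Compound 1 and compound 4 are both reported only as limits in this assay, so no step can be read for hydroxy in place of methyl on an aromatic carbon: the limit of > 50000 nM in this assay, at which 2 of the 4 values shown sit.

The compounds shown leave open whether 4-methylphenyl and 4-hydroxyphenyl differ at all in this assay.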